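From 4-ethylphenyl to 2-vinylphenyl on a shared core

The source may report more compounds than this note shows. Statements on the series, on what has been measured and on what is new or still open speak of the compounds shown alone.

In a functional assay on PC-3 cells (Homo sapiens) for cytotoxicity (on this read-out lower numbers stand for an effect already at smaller amounts and higher numbers for an effect only at larger amounts of compound), compound 2 `CCc1ccc(/C=C/C(O)=C2/C(=O)C(C)=C(OC)C(C)(C)C2=O)cc1` gives 15.1 ug/mL, and compound 1 `COC1=C(C)C(=O)/C(=C(O)/C=C/c2ccccc2OC)C(=O)C1(C)C` gives 15.6 ug/mL, so the two stand within the scatter of each other. Compound 3 `C=Cc1ccccc1/C=C/C(O)=C1/C(=O)C(C)=C(OC)C(C)(C)C1=O` keeps the shared core of compound 2 and alters only the aromatic group on the chain: 2-vinylphenyl in place of 4-ethylphenyl on a double-bonded chain carbon bound to a double-bonded chain carbon. Going by the values given here, one measured step bears on this change, a 1.0-fold lower number from compound 1 to compound 2 (0.01 log units; within the scatter). There, 4-ethylphenyl replaced 2-methoxyphenyl at the same place, and the number stayed within the scatter. Among the compounds with values here, that single exchange is all the evidence available, and no measured compound yet carries a 2-vinylphenyl group. No step beyond the scatter is therefore expected in this assay, and no direction is favoured. The expected change is a 1.0-fold lower number from compound 2 to compound 3 (0.00 log units; within the scatter). Compound 3 is estimated at 15 ug/mL, with an expected range from 8 ug/mL to 28 ug/mL.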

Compound 3, concentration for half-maximal effect: 4.6 ug/mL
Estimate against measurement, compound 3: 3.3-fold (0.51 log units) above, and the stated range ends above it.
By their numbers in this assay, from the lowest: compound 3; then compounds 2 and 1 (each within the scatter of the next).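

The earlier exchange at this place, 4-ethylphenyl for 2-methoxyphenyl, had left the number within the scatter, but in this assay this place proves responsive to the aromatic group, with 2-vinylphenyl in place of 4-ethylphenyl giving a 3.3-fold lower number from compound 2 to compound 3 (0.52 log units; beyond the scatter). Vinyl in place of methoxy on an aromatic carbon moves the number the same way, giving a 3.4-fold lower number from compound 1 to compound 3 (0.53 log units; beyond the scatter), so compound 3 stands beyond the scatter from both earlier compounds even though 2-vinylphenyl and 4-ethylphenyl have the same count of heavy atoms and differ by the double bond outside aromatic rings. Nothing available accounts for this step.

From the compounds shown here alone, what remains open is whether that double bond matters, or whether an ethyl group, a longer chain or an amine on that aromatic carbon would give a similar step. Going by these compounds, whether the step carries over to any other read-out also remains open.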